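The source may report more compounds than this note shows. Statements on the series, on what has been measured and on what is new or still open speak of the compounds shown alone.

Working notes on the series. Of the compounds shown here, three on a shared core have been measured in a functional assay for inhibition, with Homo sapiens as the target; on this read-out higher numbers stand for weaker inhibition and lower numbers for stronger inhibition. Compound 1 (`COc1cc(OC)c(C(=O)/C=C/c2ccc([N+](=O)[O-])cc2)c(OC)c1`) gives 407 nM, compound 3 (`COc1cc(OC)c(C(=O)/C=C/c2cnccn2)c(OC)c1`) gives 693 nM, and compound 2 (`COc1cc(OC)c(C(=O)/C=C/c2cccc3ccccc23)c(OC)c1`) gives 1350 nM. Compound 1 sits at the low end of these numbers, level within the scatter with compound 3, while compound 2 has a higher number, beyond the scatter.

Compound 4 (`COc1cc(OC)c(C(=O)/C=C/c2ccc(C(N)=O)cc2)c(OC)c1`) keeps the core of compound 1 and has carbamoyl in place of nitro on an aromatic carbon, para to a large group: carbamoyl in place of nitro on an aromatic carbon. For the measured compounds named here, no pair of measured compounds differs in one place only, so the series offers no direct guide to this change. Going by the values given here, the only guide is the spread of the three values, with quite different groups in this part of the structure. Those values stay within a narrow span, from compound 1 at 407 nM to compound 2 at 1350 nM.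

A modest move towards weaker inhibition in this assay is expected, near the edge of the scatter, since compound 1 starts at the low end. The expected step is a 2.0-fold higher number from compound 1 to compound 4 (0.29 log units; within the scatter). For compound 4 the estimated value is 800 nM, with an expected range of 280 nM to 2500 nM.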

Compound 4, half-maximal inhibitory concentration: 1790 nM
The estimate for compound 4 lay 2.2-fold (0.35 log units) below the measured number; the range from low to high includes it.
By their numbers in this assay, from the lowest: compounds 1, 3, 2 and 4 (each within the scatter of the next, the first and the last beyond it).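

Carbamoyl in place of nitro on an aromatic carbon, para to a large group, gives the first direct reading of a single change in this series: in this assay, the swap amounts to a 4.4-fold higher number from compound 1 to compound 4 (0.64 log units; beyond the scatter). The two groups have the same number of heavy atoms, and neither has a ring or a net charge, yet they differ in their counts of hydrogen-bond donors and acceptors, so a step beyond the scatter at this position does not require a change in heavy-atom count. Nothing measured here bears on why the number rises, and the step cannot be assigned to any one difference between the two groups.

The compounds shown leave open how an amine, a carboxylic acid or a nitrile at the same place would compare with compound 1 and compound 4. Going by these compounds, it also remains open whether a methyl-substituted carbamoyl, which has fewer amide hydrogens, would stay close to compound 4 or move towards compound 1, and a single step cannot establish a trend at this position.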